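The compounds below may be only part of what the source reports. "The series", "measured", "known", "first", "only" and "open" are said of these compounds alone.

Among the compounds with values here, compound 2 `CCC(C)c1cc(C)c(C(=O)N=C(N)N)cc1S(C)(=O)=O` is one of two compounds measured so far. In a functional assay for inhibition of sodium/hydrogen exchanger (Oryctolagus cuniculus) (a lower number here means a stronger inhibitor, a higher number a weaker inhibitor), compound 2 gives 8 nM, and compound 1 `Cc1cc(C)c(S(C)(=O)=O)cc1C(=O)N=C(N)N` gives 11 nM; the two numbers are within the scatter of each other. Within the data shown here, the only measured step is a 1.4-fold lower number from compound 1 to compound 2 (0.14 log units; within the scatter), which exchanges methyl for sec-butyl on an aromatic carbon. Compound 3 `Cc1cc(O)c(S(C)(=O)=O)cc1C(=O)N=C(N)N` differs from compound 2 by hydroxy in place of sec-butyl on an aromatic carbon. That earlier step bears only loosely on a hydroxy, so the expected step is a 1.9-fold higher number from compound 2 to compound 3 (0.27 log units; within the scatter), not clearly beyond the scatter. Compound 3 is therefore estimated at 15 nM, within a range from 5 nM to 50 nM.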

Compound 3, half-maximal inhibitory concentration: 220 nM
Beside the measured number, compound 3's estimate is 15-fold (1.17 log units) below it; the measured number lies above the stated range.
By their numbers in this assay, from the lowest: compounds 2 and 1 (each within the scatter of the next); then compound 3.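

Methyl and sec-butyl at this position, ortho to a methylsulfonyl group, gave numbers within the scatter of each other, so the position looked open to change, but hydroxy shows that it does not accept every group. In this assay, the swap to hydroxy gives a 28-fold higher number from compound 2 to compound 3 (1.44 log units; beyond the scatter), and a 20-fold higher number from compound 1 to compound 3 (1.30 log units; beyond the scatter). Nothing available here explains this loss of strength. Still open, going by these compounds, is how a methoxy group or an amine would fare at this position. These would show whether the higher number is particular to hydroxy.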